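The compounds below may be only part of what the source reports. "The series", "measured", "known", "first", "only" and "open" are said of these compounds alone.

Among the compounds with values here, in a functional assay on MV4-11 cells (Homo sapiens) for antiproliferative activity, read by resazurin assay, with a stated time of 72 h (on this read-out higher numbers stand for weaker inhibition of growth and lower numbers for stronger inhibition of growth), compound 1 (`CC(=O)N1CCN(c2ccc(Nc3ncc(C#N)c(-c4n[nH]c5ccccc45)n3)cc2)CC1`) gives 17 nM, the lower of the two numbers measured so far. Compound 2 (`CC(=O)N1CCN(c2ccc(Nc3nccc(-c4n[nH]c5ccccc45)n3)cc2)CC1`), with hydrogen in place of cyano on an aromatic carbon, gives 346 nM. Compound 3 (`CC(=O)N1CCN(c2ccc(Nc3ncc(C#N)c(-c4c(C)[nH]c5ccccc45)n3)cc2)CC1`) keeps the cyano group and exchanges the other group instead: 2-methyl-1H-indol-3-yl in place of 1H-indazol-3-yl on an aromatic carbon. Within the data shown here, no measured step touches this group. The only one available, a 20-fold higher number from compound 1 to compound 2 (1.31 log units; beyond the scatter), is large and beyond the scatter, but it concerns the cyano group, so it bears only indirectly. It shows that one change on the core of compound 1 can move the number far. The data do not fix a direction, but a moderate move toward weaker inhibition of growth is expected, and the estimated size is a 2.9-fold higher number from compound 1 to compound 3 (0.47 log units; beyond the scatter). For compound 3 the estimated value is 50 nM, with an expected range from 10 nM to 250 nM.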

Compound 3, concentration for 50% growth inhibition: 390 nM
Compound 3: middle estimate off by 7.8-fold (0.89 log units), on the low side; the measured number lies above the stated range.
By their numbers in this assay, from the lowest: compound 1; then compounds 2 and 3 (each within the scatter of the next).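

In this assay, this position, on an aromatic carbon next to the ring nitrogen and ortho to a cyano group, proves sensitive to the exchange of 1H-indazol-3-yl for 2-methyl-1H-indol-3-yl, with a 23-fold higher number from compound 1 to compound 3 (1.36 log units; beyond the scatter). Keeping the cyano group therefore does not by itself preserve the low number of compound 1, and this large step stands alongside a 20-fold higher number from compound 1 to compound 2 (1.31 log units; beyond the scatter) as a second single change that moves the number well beyond the scatter. Nothing available accounts for the size of the step.

The exchange alters two things at once, the added methyl and the ring nitrogen replaced by carbon, so the compounds shown do not say which of them goes with the step. Going by these compounds, a 1H-indol-3-yl group without the methyl, or a 2-methyl-substituted 1H-indazole attached at this place through another ring atom, remains open.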